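Phenyl in place of methyl: compound 1 to compound 4

The compounds below may be only part of what the source reports. "The series", "measured", "known", "first", "only" and "open" are said of these compounds alone.

Compound 1 `CCCCCc1nc2ccccc2[nH]1` gives 3.43
Compound 2 `O=[N+]([O-])c1cc(Cl)cc2[nH]cnc12` gives 3.01
Compound 3 `CCCc1nc2cc(C)c(C)cc2[nH]1` gives 3.4

In a physicochemical assay for lipophilicity (on this read-out lower numbers stand for lower lipophilicity and higher numbers for higher lipophilicity), compound 1 stands at 3.43 and so sits within the usual scatter of compound 3, while compound 2 lies lower, beyond that scatter. Compound 4 `c1ccc(CCCCc2nc3ccccc3[nH]2)cc1` carries phenyl in place of methyl on a saturated chain carbon, four bonds along the chain from an aromatic carbon and is otherwise the same as compound 1. Within the data shown here, no measured pair here differs in one place, so no measured step guides the size of this change. In this assay a rise beyond the scatter is expected, an estimated step of a number 0.97 log units higher from compound 1 to compound 4 (beyond the scatter) upward. Compound 4 is estimated at 4.4 with an expected range of 4 to 4.8 in that measurement.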

Compound 4, partition coefficient: 4.96
Compound 4: middle estimate off by 0.56 log units, on the low side; measured number above the stated range.
By their numbers in this assay, from the lowest: compound 2; then compounds 3 and 1 (each within the scatter of the next); then compound 4.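

In this assay, phenyl in place of methyl on a saturated chain carbon, four bonds along the chain from an aromatic carbon, gives a large change: a number 1.53 log units higher from compound 1 to compound 4 (beyond the scatter). This is the only step among these compounds that isolates a single change, so this position now has a measured size of change where the earlier compounds offered none. Nothing measured here explains the size of this step.

On these data alone, whether an amine, a carboxylic acid or a longer chain at this position would move the number as far remains open. So does whether phenyl would give a similar step on another core.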